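The source may report more compounds than this note shows. Statements on the series, on what has been measured and on what is new or still open speak of the compounds shown alone.

In a functional assay on A549 cells (Homo sapiens) for inhibition, read by MTT assay, with a stated time of 48 h (on this read-out lower numbers stand for stronger inhibition and higher numbers for weaker inhibition), compound 1 `Nc1n[nH]c2cccc(-c3cccc(NC(=O)Nc4cccc(F)c4)c3)c12` gives 1360 nM and compound 3 `Nc1n[nH]c2cccc(-c3cccc(NC(=O)Nc4ccccc4F)c3)c12` gives 1170 nM, so compound 3 stands level with compound 1. Compound 2 `Nc1n[nH]c2cccc(-c3cccc(NC(=O)Nc4ccc(Cl)cc4Cl)c3)c12` reads > 500000 nM, which is a limit of the assay. Compound 4 `Nc1n[nH]c2cccc(-c3cccc(NC(=O)Nc4cccc(C(F)(F)F)c4)c3)c12` carries 3-(trifluoromethyl)phenyl in place of 2-fluorophenyl on an amide-type nitrogen. For the measured compounds named here, two measured steps bear on this change. Exchanging one fluorophenyl group for the other gave the small 1.2-fold lower number from compound 1 to compound 3 (0.07 log units; within the scatter), while replacing 2,4-dichlorophenyl with 2-fluorophenyl gave the large at least 420-fold lower number from compound 2 to compound 3 (2.63 log units; beyond the scatter). Taking the fluorophenyl exchange as the nearer precedent, no step beyond the scatter is expected in this assay, only a slight rise, though the large step leaves some upward risk. The expected step is a 1.7-fold higher number from compound 3 to compound 4 (0.23 log units; within the scatter). Compound 4 is estimated at 2000 nM, with an expected range of 600 nM to 15000 nM.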

Compound 4, half-maximal inhibitory concentration: 1950 nM
Beside the measured number, compound 4's estimate is 1.0-fold (0.01 log units) above it; measured number inside the range.
By their numbers in this assay, from the lowest: compounds 3, 1 and 4 (each within the scatter of the next). At a limit, above all of these: compound 2.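

In this assay, 3-(trifluoromethyl)phenyl on this amide-type nitrogen gives a 1.7-fold higher number from compound 3 to compound 4 (0.22 log units; within the scatter), and trifluoromethyl in place of fluoro on an aromatic carbon gives a 1.4-fold higher number from compound 1 to compound 4 (0.16 log units; within the scatter), so compound 4 stands level with both fluorophenyl compounds. For the compounds shown here, the only large step to compound 4 is an at least 250-fold lower number from compound 2 to compound 4 (2.40 log units; beyond the scatter). That step rests on compound 2, whose value is a limit: the limit of > 500000 nM in this assay, at which 1 of the 4 values shown sits.

The compounds shown leave open whether 2,4-dichlorophenyl alone separates compound 2 from the others, and how an amine or a carboxylic acid on this phenyl ring would read.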